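A few compounds are considered here, and "the series" means these few. Any claim that something is new, unique, unknown or untested is made for them only; others in the source may bear on it.

Measured compounds:
compound 1, `Nc1nc(Br)cn2cc(-c3ccco3)nc12`, with 210 nM in an assay on cells for displacement of a labelled ligand from adenosine receptor A1 (Homo sapiens), read by scintillation counting, with a stated time of 120 min; on this read-out lower numbers stand for stronger inhibition and higher numbers for weaker inhibition
compound 2, `Nc1nc(-c2ccccc2)cn2cc(-c3ccco3)nc12`, with 143 nM in this assay

Going by the values given here, compound 2 gives the lowest of the two numbers so far, but its nearest neighbour, compound 1, sits within the scatter of it, so the two cannot be ranked against each other. Among the compounds with values here, the only single change measured here is the one from compound 1 to compound 2, where a 1.5-fold lower number from compound 1 to compound 2 (0.17 log units; within the scatter); this says that swapping bromo for phenyl at this position hardly moved the number.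

Compound 3, `Nc1nc(-c2ccco2)cn2cc(-c3ccco3)nc12`, has not yet been measured. It differs from compound 2 in one place: furan-2-yl in place of phenyl on an aromatic carbon. Within the data shown here, no measured pair in this set compares a phenyl with a furan-2-yl, so the step from compound 1 to compound 2 is only an indirect guide, showing that the position tolerates two quite different groups without a step beyond the scatter.

For that reason the number for compound 3 is expected to stay close to that of compound 2, with an expected step of a 1.2-fold lower number from compound 2 to compound 3 (0.08 log units; within the scatter). The estimate for compound 3 in this assay is 120 nM, with a range from 40 nM to 360 nM.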

Compound 3, inhibition constant: 316 nM
The estimate for compound 3 lay 2.6-fold (0.42 log units) below the measured number; the measured number falls inside the stated range.
By their numbers in this assay, from the lowest: compounds 2, 1 and 3 (each within the scatter of the next, the first and the last beyond it).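

Swapping phenyl for furan-2-yl at this position gives a 2.2-fold higher number from compound 2 to compound 3 (0.34 log units; beyond the scatter) in this assay, the first step at this position that lies beyond the scatter, though it is only modest. Set against bromo, the same furan-2-yl gives a 1.5-fold higher number from compound 1 to compound 3 (0.18 log units; within the scatter), so compound 3 and compound 1 cannot be ranked, and only compound 2 and compound 3 can be told apart. The position is therefore not entirely indifferent to what it carries, since two aromatic rings that differ in ring size and in a single oxygen atom are not fully interchangeable here, but no information is available to explain the gap between them.

The phenyl and furan-2-yl rings differ in several counted ways at once, so these compounds leave open whether ring size or the oxygen atom matters more, a question that thiophen-2-yl, a five-membered ring with sulfur in place of oxygen, could help to separate. Also open, going by these compounds, is how non-aromatic groups at this position, such as methyl or a morpholine ring, would compare.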